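The compounds below may be only part of what the source reports. "The series", "measured", "known", "first", "only" and "open" are said of these compounds alone.

Compound 2, whose structure is `C/C(=N\NC(=O)c1cccc(S(=O)(=O)N2CCOCC2)c1)c1ccc(F)cc1`, is one of two measured compounds built on a shared core. In a functional assay on ECa-109 cells for antiproliferative activity against ECa-109 cell line (Homo sapiens), read by MTT assay, with a stated time of 72 h (a higher number here means a weaker inhibitor, a lower number a stronger inhibitor), compound 2 gives only a limit of > 100000 nM, not a number. Compound 1, with structure `C/C(=N\NC(=O)c1cccc(S(=O)(=O)N2CCOCC2)c1)c1cccc(N)c1`, differs from it in one place. In this assay compound 1 also gives only a limit, > 100000 nM. The step from compound 1 to compound 2 therefore cannot be read: a step that the two limits leave unreadable from compound 1 to compound 2. Both measured values sit at the same point, (the limit of > 100000 nM in this assay, at which 2 of the 2 values shown sit), so the data contain no readable step at all.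

Compound 3, with structure `C/C(=N\NC(=O)c1cccc(S(=O)(=O)N2CCOCC2)c1)c1ccccc1O`, differs from compound 2 by one change: 2-hydroxyphenyl in place of 4-fluorophenyl on a carbon with a double bond to nitrogen. Among the compounds with values here, no measured step bears on this change, and the two values that exist are both limits, so no direction or size can be taken from them.

Compound 3 is therefore expected to show a change of about a step that the limit leaves unreadable from compound 2 to compound 3 from compound 2, that is, none that can be read. For compound 3 the estimated value in this assay is 150000 nM, with a range from 40000 nM to 600000 nM, and the outcome is most likely again a limit.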

Compound 3, half-maximal inhibitory concentration: 5450 nM
Compound 3: middle estimate off by 28-fold (1.44 log units), on the high side; the whole stated range lies above it.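

This position on the shared core, the aryl group on a carbon with a double bond to nitrogen, turns out to matter in this assay, which the first two compounds could not show. Placing 2-hydroxyphenyl there in place of 4-fluorophenyl gives an at least 18-fold lower number from compound 2 to compound 3 (1.26 log units; beyond the scatter), and placing it there in place of 3-aminophenyl gives an at least 18-fold lower number from compound 1 to compound 3 (1.26 log units; beyond the scatter). Compound 3 is thus the only one of the three with a measured number rather than a limit, while the other two share one: the limit of > 100000 nM in this assay, at which 2 of the 3 values shown sit.

The compounds shown leave open whether the hydroxyl group itself or its place on the ring carries this gain, since 4-fluorophenyl and 2-hydroxyphenyl differ in both the group and its ring position, and 3-aminophenyl also differs from 2-hydroxyphenyl in both. A 4-hydroxyphenyl or 3-hydroxyphenyl group would separate group from position, while a 2-methoxyphenyl or 2-aminophenyl group would test whether the hydroxyl hydrogen or another group at that ring position gives a comparable value.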